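The source may report more compounds than this note shows. Statements on the series, on what has been measured and on what is new or still open speak of the compounds shown alone.

With a physicochemical assay for solubility, read by HPLC, in phosphate buffer, at pH 6.5 (on this read-out lower numbers stand for lower solubility and higher numbers for higher solubility), on the shared core, compound 1 `COC(=O)C1=C(CN2CCCCC2)NC(c2nccs2)=NC1(C)c1ccc(F)cc1` gives 282 ug/mL, compound 2 `COC(=O)C1=C(CN2CCNCC2)NC(c2nccs2)=NC1(C)c1ccc(F)cc1` gives 250 ug/mL and compound 3 `COC(=O)C1=C(CN2CC3CC2CO3)NC(c2nccs2)=NC1(C)c1ccc(F)cc1` gives 564 ug/mL. Compound 3 stands clear of only one of these: a 2.3-fold higher number from compound 2 to compound 3 (0.35 log units; beyond the scatter), against a 2.0-fold higher number from compound 1 to compound 3 (0.30 log units; within the scatter). Compound 4 `COC(=O)C1=C(CN2CCOCC2=O)NC(c2nccs2)=NC1(C)c1ccc(F)cc1` carries a group of 7 heavy atoms (4 carbon, 1 nitrogen, 2 oxygen; one six-membered non-aromatic ring with 2 hetero atoms) in place of a group of 7 heavy atoms (5 carbon, 1 nitrogen, 1 oxygen; 2 five-membered non-aromatic rings with 1 hetero atom each), on a saturated chain carbon bound to a double-bonded ring carbon.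

The three measured steps at this place bear on the change. Besides those two, there is a 1.1-fold lower number from compound 1 to compound 2 (0.05 log units; within the scatter), so all are small. Compound 4 returns to a single six-membered ring, as in compound 1 and compound 2. No step beyond the scatter is therefore expected in this assay, and the expected step is a 1.9-fold lower number from compound 3 to compound 4 (0.27 log units; within the scatter). The estimate for compound 4 is 300 ug/mL, with an expected range of 110 ug/mL to 750 ug/mL.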

Compound 4, solubility: 440 ug/mL
Estimate against measurement, compound 4: 1.5-fold (0.17 log units) below; measured number inside the range.
By their numbers in this assay, from the lowest: compounds 2, 1, 4 and 3 (each within the scatter of the next, the first and the last beyond it).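

In this assay the 3-oxomorpholin-4-yl group at this place stays within the scatter of all three groups before it, with a 1.3-fold lower number from compound 3 to compound 4 (0.11 log units; within the scatter) and a 1.8-fold higher number from compound 2 to compound 4 (0.25 log units; within the scatter) and a 1.6-fold higher number from compound 1 to compound 4 (0.19 log units; within the scatter) as its steps. A single six-membered ring carrying this group therefore separates from neither the piperidin-1-yl nor the piperazin-1-yl compound, nor from the compound with two five-membered rings. Nothing available accounts for these numbers. As far as these compounds go, what remains open is whether a carboxylic acid or a longer chain ending in an amine at this place would step beyond the scatter.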